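The source may hold more compounds than are shown below. What is called first, only, known or untested is meant among the compounds shown, and "the series" means these compounds.

Compound 1 `COc1ccc(C2N=C(SCc3ccc(Cl)cc3)NC(C)=C2C(=O)Nc2ccc(F)cc2)cc1OC` in a functional assay on the whole organism (artery, strain albino) with Rattus norvegicus as the target, with a stated time of 900 min, at a dose of 10 mg/kg by the oral route (on this read-out higher numbers stand for more inhibition at the one dose given (going by the name of the read-out) and lower numbers for less inhibition), gives 20%. Within the data shown here, compound 2 `COc1ccc(C2N=C(SCc3ccc(F)cc3)NC(C)=C2C(=O)Nc2ccc(F)cc2)cc1OC` in this assay gives 15.4%, and the only other number, that of compound 1, sits within the scatter of it, since a number 4.6 percentage points lower from compound 1 to compound 2 (within the scatter). Compound 3 `CC1=C(C(=O)Nc2ccc(F)cc2)C(c2ccc([N+](=O)[O-])cc2)N=C(SCc2ccc(F)cc2)N1` carries 4-nitrophenyl in place of 3,4-dimethoxyphenyl on a saturated ring carbon. Among the measured compounds shown here, no measured step touches this saturated ring carbon; the single measured step concerns fluoro in place of chloro on an aromatic carbon and lies within the scatter, so nothing anchors the size of the change in this assay. Compound 3 is therefore expected to give 16%, within 4% to 32%. The expected step is a number 0.6 percentage points higher from compound 2 to compound 3 (within the scatter), nothing beyond the scatter.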

Compound 3, a percentage reported as inhibition, in the whole organism at one dose (the size of the read-out at that dose, not a potency): 13.8%
Estimate against measurement, compound 3: 2.2 percentage points above, and the stated range covers the measured number.
By their numbers in this assay, from the lowest: compounds 3, 2 and 1 (each within the scatter of the next).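

The saturated ring carbon now has a measured step of its own in this assay: a number 1.6 percentage points lower from compound 2 to compound 3 (within the scatter) and so 4-nitrophenyl in place of 3,4-dimethoxyphenyl does not move the read-out beyond the scatter at this position. Two aromatic rings of different substitution are therefore not told apart at the one dose given. Nothing available bears on why this is so.

On these data alone, whether an amine or a carboxylic acid on the aromatic ring at this carbon would give a step beyond the scatter stays open. Also open, as far as these compounds go, is whether this change would give the same step with the (4-chlorobenzyl)sulfanyl group of compound 1 in place of the (4-fluorobenzyl)sulfanyl group.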